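Swapping Trifluoromethyl for an Ester Chain in Compound 4

The source may hold more compounds than are shown below. What is called first, only, known or untested is meant among the compounds shown, and "the series" means these compounds.

Three compounds have been measured in a functional assay for agonist activity at G protein-coupled receptor 88 (Homo sapiens), read by HTRF and cAMP accumulation; a lower number here means that less compound is needed, a higher number that more compound is needed for the effect:

Compound 1, `CC[C@H](C)[C@@H](CN(C(=O)[C@@H]1C[C@H]1c1ccccc1)c1ccc(-c2ccccc2)cc1)NC(C)=O`: 5.8 nM
Compound 2, `CC[C@H](C)[C@H](N)CN(C(=O)[C@@H]1C[C@H]1c1ccccc1Cl)c1ccc(-c2ccccc2)cc1`: > 25000 nM, a limit of the assay, not a number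
Compound 3, `CC[C@H](C)[C@H](N)CN(C(=O)[C@@H]1C[C@H]1c1ccccc1)c1ccc(-c2ccc(C(F)(F)F)cc2)cc1`: 340 nM

Compound 3 holds the higher of the two numbers that are numbers; compound 1 gives the lower one, and the gap between them is beyond the scatter. For compound 2 the value shown is only a limit (the limit of > 25000 nM in this assay, at which 1 of the 3 values shown sits).

Compound 4, `CC[C@H](C)[C@H](N)CN(C(=O)[C@@H]1C[C@H]1c1ccccc1)c1ccc(-c2ccc(CCC(=O)OC)cc2)cc1`, has not yet been measured. It differs from compound 3 in one place: 2-(methoxycarbonyl)ethyl in place of trifluoromethyl on an aromatic carbon. Within the data shown here, no measured pair shows this change, so its effect is unknown; in this assay a modest step in either direction, or none beyond the scatter, is expected. Compound 4 is estimated at 400 nM, between 100 nM and 2500 nM, which would mean an expected step of a 1.2-fold higher number from compound 3 to compound 4 (0.07 log units; within the scatter).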

Compound 4, half-maximal effective concentration: 110 nM
Estimate against measurement, compound 4: 3.6-fold (0.56 log units) above, within the range that was stated.
By their numbers in this assay, from the lowest: compound 1; then compound 4; then compound 3. At a limit, above all of these: compound 2.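

In this assay, 2-(methoxycarbonyl)ethyl in place of trifluoromethyl gives a 3.1-fold lower number from compound 3 to compound 4 (0.49 log units; beyond the scatter) and so takes the compound to a lower number. This aromatic carbon, para to a large group, therefore accepts a longer chain carrying hydrogen-bond acceptors without any loss in this assay. Nothing among the measurements shown explains why the number falls.

The compounds shown do not separate the contribution of the ester from that of the chain's length. A plain propyl chain or the matching carboxylic acid at this position would be needed to tell these apart.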